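Adding a chloro group to compound 1: an expectation

The source may report more compounds than this note shows. Statements on the series, on what has been measured and on what is new or still open speak of the compounds shown alone.

Within the data shown here, compound 1 `CNC1(COc2cccnc2)CC1` gives 3 nM in an assay on brain for displacement of a labelled ligand from Neuronal acetylcholine receptor; alpha4/beta2 (Rattus norvegicus) (on this read-out higher numbers stand for weaker inhibition and lower numbers for stronger inhibition), the lowest of the three numbers measured so far. Compound 3 `NC1(COc2cccnc2)CC1` gives 34 nM, and compound 2 `CN(C)C1(COc2cccnc2)CC1` gives 95 nM. Both steps away from compound 1 are large: an 11-fold higher number from compound 1 to compound 3 (1.05 log units; beyond the scatter) and a 32-fold higher number from compound 1 to compound 2 (1.50 log units; beyond the scatter), and both are changes at the amine nitrogen. Compound 4 `CNC1(COc2ccc(Cl)nc2)CC1` is not yet measured; it differs from compound 1 by chloro in place of hydrogen on an aromatic carbon, on an aromatic carbon of a six-membered aromatic ring with 1 nitrogen. Among the measured compounds shown here, none of the measured steps touches that ring, so none bears directly on this change. The expectation therefore rests on the value of compound 1, 3 nM. A step of a 2.0-fold lower number from compound 1 to compound 4 (0.30 log units; within the scatter) is expected. Compound 4 is estimated at 1.5 nM, between 0.3 nM and 8 nM.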

Compound 4, inhibition constant: 13 nM
Beside the measured number, compound 4's estimate is 8.7-fold (0.94 log units) below it, and the stated range ends below it.
By their numbers in this assay, from the lowest: compound 1; then compound 4; then compound 3; then compound 2.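

In this assay chloro in place of hydrogen on an aromatic carbon, next to the ring nitrogen, gives a 4.3-fold higher number from compound 1 to compound 4 (0.64 log units; beyond the scatter), the first measured step away from the amine nitrogen. The number therefore responds to a change on the aromatic ring as well, although this modest step is smaller than the large steps at the amine nitrogen of compound 1. No measurement shown explains this step. As far as these compounds go, it remains open whether fluoro, methoxy or an amino group at this place would give a higher or lower number. From the compounds shown here alone, it also remains open whether chloro would have the same effect on compound 2 or compound 3.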